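The compounds below may be only part of what the source reports. "The series", "measured", "known", "first", "only" and "open" are said of these compounds alone.

Three compounds sharing one hydroxamic acid end and one core have been tested in an assay on isolated protein for inhibition of histone deacetylase HD2 (Zea mays); a lower number here means a stronger inhibitor, a higher number a weaker inhibitor. Compound 1 `O=C(/C=C/c1cccc(CSc2nc(O)cc(-c3ccccc3)n2)c1)NO` gives 17 nM. Compound 2 `CC(c1ccccc1)c1cc(O)nc(SCCCCCC(=O)NO)n1` gives 9 nM. Compound 3 `CCC(c1ccccc1)c1cc(O)nc(SCCCCCC(=O)NO)n1` gives 32 nM, the highest of the three numbers, though its gap to compound 1 lies within the usual scatter of repeated measurements. Going by the values given here, its gap to compound 2 does not: a 3.6-fold higher number from compound 2 to compound 3 (0.55 log units; beyond the scatter), which counts as a modest change, and this is the only step among the measured compounds that touches the carbon where compound 4 will differ.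

Compound 4 `COC(c1ccccc1)c1cc(O)nc(SCCCCCC(=O)NO)n1` departs from compound 3 in one place: methoxy in place of ethyl on a saturated chain carbon bound to two aromatic carbons. Among the compounds with values here, the group leaving and the group entering are of the same size in heavy atoms, and the one measured step at this carbon, a change of branch size, shifted the number only modestly. Nothing among the three measured compounds shows what swapping a carbon for an oxygen at this place does, so the expectation for compound 4 is a step of a 1.3-fold lower number from compound 3 to compound 4 (0.11 log units; within the scatter), one that may well stay within the scatter. The estimate for compound 4 in this assay is therefore 25 nM, with a plausible range from 9 nM to 70 nM.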

Compound 4, half-maximal inhibitory concentration: 82 nM
Beside the measured number, compound 4's estimate is 3.3-fold (0.52 log units) below it; the whole stated range lies below it.
By their numbers in this assay, from the lowest: compounds 2, 1 and 3 (each within the scatter of the next, the first and the last beyond it); then compound 4.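

In this assay the saturated chain carbon bound to two aromatic carbons proves sensitive to more than the heavy-atom count of its branch: ethyl and methoxy both have 2 heavy atoms, yet the swap gives a 2.6-fold higher number from compound 3 to compound 4 (0.41 log units; beyond the scatter). Replacing one carbon of the branch with an oxygen therefore moves the number beyond the scatter, and the step is of similar standing to the one seen earlier for methyl to ethyl, while methoxy in place of methyl gives the largest shift among these three compounds, with a 9.1-fold higher number from compound 2 to compound 4 (0.96 log units; beyond the scatter). No measurement shown here explains why methoxy behaves this way at this carbon.

One swap cannot separate the effect of the oxygen from that of the particular group that carries it, and a hydroxyl, an amine or a longer chain such as propyl at this carbon would help to tell which matters. On these data alone, whether the same order of methyl, ethyl and methoxy would hold on a different core, such as that of compound 1, or with a plain hydrogen at this carbon also remains open.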